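The compounds below may be only part of what the source reports. "The series", "measured", "known", "first", "only" and "open" are said of these compounds alone.

Compound 1 `Cc1cn2c(-c3cn[nH]c3)cnc2c(Nc2cc(Cc3nccs3)ns2)n1`: 1540 ng.h/mL
Compound 2 `Cc1cn2c(-c3cn[nH]c3)cnc2c(Nc2cc(Cc3cnccn3)ns2)n1`: 58.4 ng.h/mL

In an ADME assay on the whole organism for pharmacokinetics, with Rattus norvegicus as the target, with a stated time of 6 h, at a dose of 10 mg/kg by the oral route (a lower number here means less compound in the circulation, a higher number more compound in the circulation at the dose given), compound 2 gives the lowest of the two numbers; its nearest neighbour is compound 1. For the measured compounds named here, the one measured step, a 26-fold lower number from compound 1 to compound 2 (1.42 log units; beyond the scatter), shows a large drop when the six-membered ring with two heteroatoms replaces the five-membered one. Compound 3 `Cc1cn2c(-c3cn[nH]c3)cnc2c(Nc2cc(Cc3ccccn3)ns2)n1` carries pyridin-2-yl in place of pyrazin-2-yl on a saturated chain carbon bound to an aromatic carbon. Since this removes one of the two heteroatoms that came in with compound 2, an upward step toward compound 1 is expected, though its size is uncertain. Compound 3 is therefore estimated at 350 ng.h/mL, within 70 ng.h/mL to 1800 ng.h/mL, an expected step of a 6.0-fold higher number from compound 2 to compound 3 (0.78 log units; beyond the scatter).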

Compound 3, area under the concentration-time curve: 6880 ng.h/mL
Compound 3: the middle estimate sits 20-fold (1.29 log units) below what was measured; measured number outside the range, above it.
By their numbers in this assay, from the lowest: compound 2; then compound 1; then compound 3.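

On a saturated chain carbon bound to an aromatic carbon, the six-membered ring does not itself bring the low number in this assay: pyridin-2-yl in place of pyrazin-2-yl gives a 120-fold higher number from compound 2 to compound 3 (2.07 log units; beyond the scatter), a change of one ring nitrogen to carbon. The same ring also exceeds the five-membered one, with a 4.5-fold higher number from compound 1 to compound 3 (0.65 log units; beyond the scatter). No measurement available here accounts for the size of these steps.

Still open, as far as these compounds go, is how a phenyl ring, with no ring nitrogen, would read at this place. Also open, from the compounds shown here alone, is whether pyrimidin-2-yl would fall as low as pyrazin-2-yl.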